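Anilino variation on a shared core: estimating compound 4

The compounds below may be only part of what the source reports. "The series", "measured", "known", "first", "only" and "open" are said of these compounds alone.

The measured compounds and their numbers:
Compound 1, `Cc1n[nH]c2ccc(-c3nc4cnc(N5CCN(C)CC5)cn4c3Nc3ccc(I)cc3)cc12`, gives 0% in a functional assay on MV4-11 cells (Homo sapiens) for inhibition, with a stated time of 120 h, tested at 10 uM; a higher number here means more inhibition at the concentration tested (going by the name of the read-out), a lower number less inhibition.
Compound 2, `Cc1n[nH]c2ccc(-c3nc4cnc(N5CCN(C)CC5)cn4c3Nc3ccc(Cl)cc3F)cc12`, gives 0% in this assay.
Compound 3, `Cc1cc(Br)ccc1Nc1c(-c2ccc3[nH]nc(C)c3c2)nc2cnc(N3CCN(C)CC3)cn12`, gives 59.4% in this assay.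

Compound 1 stands level with compound 2, the two together the lowest of the three numbers, while compound 3 lies far above both. Replacing the aryl group on the ring nitrogen gave no change at the digits printed from compound 1 to compound 2 (within the scatter) but a number 59.4 percentage points higher from compound 1 to compound 3 (beyond the scatter), and likewise a number 59.4 percentage points higher from compound 2 to compound 3 (beyond the scatter). The aryl group on this nitrogen therefore decides between no measurable inhibition and a large one.

Compound 4, `COc1ccc(Nc2c(-c3ccc4[nH]nc(C)c4c3)nc3cnc(N4CCN(C)CC4)cn23)cc1OC`, is the next compound on the same core. It differs from compound 1 in one place: 3,4-dimethoxyphenyl in place of 4-iodophenyl on a nitrogen on an aromatic ring. For the measured compounds named here, no measured step introduces a dimethoxy pattern; the only change that raised inhibition carried a 4-bromo-2-methylphenyl, and the change to 4-chloro-2-fluorophenyl left the number unmoved. Going by the values given here, the step to compound 4 thus has no close precedent, and the two flat numbers of compound 1 and compound 2 weigh against a large rise. A modest step is expected, a number 15 percentage points higher from compound 1 to compound 4 (beyond the scatter), with wide uncertainty. Compound 4 is estimated at 15%, within a range from 0% to 55%.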

Compound 4, a percentage reported as inhibition, at one concentration (the size of the read-out at that concentration, not a potency): 6.27%
Compound 4: middle estimate off by 8.7 percentage points, on the high side; low and high end bracket the measured number.
By their numbers in this assay, from the lowest: compounds 1, 2 and 4 (each within the scatter of the next); then compound 3.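

In this assay, putting 3,4-dimethoxyphenyl on the nitrogen gives a number 6.3 percentage points higher from compound 1 to compound 4 (within the scatter) and a number 6.3 percentage points higher from compound 2 to compound 4 (within the scatter), so this third aryl group joins 4-iodophenyl and 4-chloro-2-fluorophenyl at the low end of the series. Set against the one group that stood out, the same change gives a number 53.1 percentage points lower from compound 3 to compound 4 (beyond the scatter), which leaves 4-bromo-2-methylphenyl alone among the four aryl groups in reaching a large number. The result also shows that the hydrogen-bond acceptors counted on 3,4-dimethoxyphenyl, which 4-iodophenyl lacks, and its larger heavy-atom count come with no step beyond the scatter at this position.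

No accompanying measurement accounts for the gap between compound 3 and the other three compounds. The compounds shown also leave open whether the bromine or the methyl of compound 3 carries its number, which a 4-bromophenyl or a 2-methylphenyl group would separate, and how an aryl group bearing an amine or a carboxylic acid would read at this nitrogen.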